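The compounds below may be only part of what the source reports. "The series", "measured", "known", "first", "only" and "open" are said of these compounds alone.

Measured in a functional assay on NCI/ADR-RES cells (Homo sapiens) for cytotoxicity; a higher number here means a weaker inhibitor of growth, a lower number a stronger inhibitor of growth:
- Compound 1 `COc1ccc(NS(=O)(=O)c2c(F)c(F)c(F)c(F)c2Br)cc1`: 160 nM
- Compound 2 `COc1ccc(NS(=O)(=O)c2c(F)cc(F)c(F)c2F)cc1`: 4500 nM
- Compound 3 `COc1ccc(NS(=O)(=O)c2c(F)c(F)c(Br)c(F)c2F)cc1`: 21000 nM

Compound 3 has the highest number of the three in this assay, at 21000 nM. Compound 2 stands clearly lower at 4500 nM, and compound 1 stands much lower still at 160 nM.

Compound 4 `COc1ccc(NS(=O)(=O)c2c(F)c(F)c(F)c(F)c2F)cc1` has not yet been measured. It differs from compound 3 at a single place, with fluoro in place of bromo on an aromatic carbon, para to a large group (fluoro in place of bromo on an aromatic carbon).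

For the measured compounds named here, no measured pair isolates this change, so the expectation rests on indirect evidence. Of the measured compounds, only compound 1 carries fluoro on that carbon, and it gives 160 nM, although it also holds a bromo at another place. Compound 3, with bromo on that carbon, gives 21000 nM. Compound 2, with neither group there, gives 4500 nM.

On this comparison, a large fall in the number, well beyond the scatter, is expected, and the estimated change is a 210-fold lower number from compound 3 to compound 4 (2.32 log units; beyond the scatter). For compound 4 the expected value is 100 nM, with an estimated range of 30 nM to 400 nM.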

Compound 4, concentration for 50% growth inhibition: 58 nM
For compound 4 the middle estimate is 1.7-fold (0.24 log units) above the measured one, within the range that was stated.
By their numbers in this assay, from the lowest: compound 4; then compound 1; then compound 2; then compound 3.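

In this assay, the carbon para to a large group turns out to be highly sensitive to the halogen it carries, since fluoro in place of bromo there gives a 360-fold lower number from compound 3 to compound 4 (2.56 log units; beyond the scatter). The same exchange of bromo for fluoro at another aromatic carbon gives only a 2.8-fold lower number from compound 1 to compound 4 (0.44 log units; beyond the scatter), so the size of this change depends strongly on where it is made, although both steps lie beyond the scatter. Fluoro in place of hydrogen on an aromatic carbon also counts for much, with a 78-fold lower number from compound 2 to compound 4 (1.89 log units; beyond the scatter), and compound 4 now has the lowest number of the four, with its steps to all the others beyond the scatter.

Nothing given here explains why the same exchange differs so much between the two places. Going by these compounds, it also remains open how an amine, a nitrile or a methyl group would compare with fluoro and bromo on the carbon para to a large group, and whether a longer chain in place of the methoxy group would keep the low number of compound 4.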